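The source may hold more compounds than are shown below. What is called first, only, known or untested is meant among the compounds shown, and "the series" means these compounds.

The measured compounds:

Compound 1, `CSc1ccc(CNc2nc([SeH])nc3ccccc23)cc1`. In a functional assay on HT-29 cells (Homo sapiens) for cytotoxicity, read by MTT assay, with a stated time of 72 h (on this read-out higher numbers stand for weaker inhibition of growth and lower numbers for stronger inhibition of growth), compound 1 gives > 100000 nM, which is a limit of the assay and not a number.

Compound 2, `CCCCCSc1nc(NCc2ccc([Se]C)cc2)c2ccccc2n1`. In this assay compound 2 gives > 100000 nM, likewise a limit.

Compound 3, `CSc1nc(NCc2ccc([Se]C)cc2)c2ccccc2n1`. In this assay compound 3 gives > 100000 nM, again a limit.

Compound 3 therefore stands only at a limit in this assay, and the two other values shown are limits as well; all three sit at the limit of > 100000 nM in this assay, at which 3 of the 3 values shown sit. Among the compounds with values here, the one measured step that touches compound 3, a step that the two limits leave unreadable from compound 2 to compound 3, is hydrogen in place of butyl on a saturated chain carbon bound to a sulfur, and its size cannot be read from the two limits.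

Compound 4, `CSc1ccc(CNc2nc(SC)nc3ccccc23)cc1`, differs from compound 3 by a group of 2 heavy atoms (1 carbon, 1 sulfur; no ring) in place of a group of 2 heavy atoms (1 carbon, 1 selenium; no ring), on an aromatic carbon. Within the data shown here, no measured step alters this group, so nothing in the data bears directly on it. Given that all three values sit at the limit of > 100000 nM in this assay, at which 3 of the 3 values shown sit, the step from compound 3 to compound 4 in this assay is expected to be a number no higher from compound 3 to compound 4 (the limit leaves the size open), with no change that could be read. Compound 4 is accordingly estimated at 100000 nM, within a range of 30000 nM to 300000 nM, and most probably reported only as a limit.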

Compound 4, concentration for total growth inhibition: > 100000 nM
Compound 4: only a limit was reported; the forecaster's own chance of this, stated with the estimate: 80%; the middle value sits exactly at the limit.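

In this assay compound 4 gives > 100000 nM, which is a limit and not a number. The steps to compound 4 from compound 3 and from compound 1 therefore cannot be read. The compounds shown leave open whether any of these changes alters growth inhibition: the limit of > 100000 nM in this assay, at which 4 of the 4 values shown sit.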